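The compounds below may be only part of what the source reports. "The series", "measured", "known", "first", "only" and "open" are said of these compounds alone.

Working notes on the series.

Three measured compounds share one core and differ only in where a single chloro sits on the fused two-ring part. In a functional assay on HEK293 cells for agonist activity at Free fatty acid receptor 1 (Homo sapiens), read by fluorescence and calcium flux, with a stated time of 10 min (a lower number here means that less compound is needed, a higher number that more compound is needed for the effect), compound 1 `CC#C[C@@H](CC(=O)O)c1ccc(OC[C@H]2COc3c(Cl)cccc3O2)cc1` gives 170 nM. Compound 2 `CC#C[C@@H](CC(=O)O)c1ccc(OC[C@H]2COc3cc(Cl)ccc3O2)cc1` gives 110 nM in this assay. Compound 3 `CC#C[C@@H](CC(=O)O)c1ccc(OC[C@H]2COc3cccc(Cl)c3O2)cc1` gives 520 nM in this assay, the highest of the three numbers; the gap to compound 1 and to compound 2 lies beyond the scatter in each case, so compound 3 needs the most compound of the set for the effect.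

The next compound is the unsubstituted parent, compound 4 `CC#C[C@@H](CC(=O)O)c1ccc(OC[C@H]2COc3ccccc3O2)cc1`. Relative to compound 3 the change is hydrogen in place of chloro on an aromatic carbon. For the measured compounds named here, no step between measured compounds removes a chloro outright, so the size of the step rests on reading the three chloro isomers together: the number falls noticeably when the chloro sits elsewhere, and removing it altogether is expected to bring the number back toward the range of compound 1 and compound 2, rather than beyond it.

For compound 4 the estimated value in this assay is 200 nM, within a range of 80 nM to 500 nM. This estimate means a step from compound 3 to compound 4 of a 2.6-fold lower number from compound 3 to compound 4 (0.41 log units; beyond the scatter), expected to lie beyond the scatter.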

Compound 4, half-maximal effective concentration: 90 nM
For compound 4 the middle estimate is 2.2-fold (0.35 log units) above the measured one; the measured number falls inside the stated range.
By their numbers in this assay, from the lowest: compounds 4, 2 and 1 (each within the scatter of the next); then compound 3.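

Replacing the chloro of compound 3 with hydrogen gives a 5.8-fold lower number from compound 3 to compound 4 (0.76 log units; beyond the scatter) in this assay and shows directly that the chloro at this place raises the number, which the three chloro isomers could only suggest when compared with each other. The same replacement gives a 1.2-fold lower number from compound 2 to compound 4 (0.09 log units; within the scatter) and a 1.9-fold lower number from compound 1 to compound 4 (0.28 log units; within the scatter) in the same assay, so the chloro at either of those two places leaves the number within the scatter of the unsubstituted parent, and among these three chloro places only the one in compound 3 carries a step beyond it. The series therefore shows a chloro effect that depends on place, although no supporting measurement bears on the reason for this difference.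

The compounds shown leave open whether the rise seen with chloro at the place it holds in compound 3 also follows with a smaller fluoro or with a different group such as methoxy or an amine. They also leave open whether a methyl, a methoxy or a nitrile at the two places where chloro leaves the number unchanged would lower the number below that of compound 4 or raise it.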